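Widening the Amide Ring on a Translocator Protein Ligand

This account rests on a few compounds, and the source may have more. Where it says the series, first, only, none or still open, it means among the compounds named here.

Of the compounds shown here, three that share one core have been measured in an assay on C6 cells for displacement of a labelled ligand from Translocator protein (Rattus norvegicus), read by scintillation counting, with a stated time of 2 h; a lower number here means a stronger inhibitor, a higher number a weaker inhibitor. Compound 1 `CCc1cc(CC)n2nc(-c3ccc(OC)cc3)c(CC(=O)N(C)C)c2n1` carries a dimethylamino group on the carbonyl carbon and in this assay gives 37.6 nM. Compound 2 `CCCCCN(CCCCC)C(=O)Cc1c(-c2ccc(OC)cc2)nn2c(CC)cc(CC)nc12` carries a dipentylamino group in that place and gives 2.17 nM. Compound 3 `CCc1cc(CC)n2nc(-c3ccc(OC)cc3)c(CC(=O)N3CCC3)c2n1` carries an azetidin-1-yl group there and gives 87.8 nM, the highest of the three numbers; the move from the dimethylamino compound reads a 2.3-fold higher number from compound 1 to compound 3 (0.37 log units; beyond the scatter), and against the dipentylamino compound it reads a 40-fold higher number from compound 2 to compound 3 (1.61 log units; beyond the scatter).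

Compound 4 `CCc1cc(CC)n2nc(-c3ccc(OC)cc3)c(CC(=O)N3CCCC3)c2n1` is the next step from compound 3: pyrrolidin-1-yl in place of azetidin-1-yl on a carbonyl carbon. Among the compounds with values here, two measured steps bear on it, both changing the group on the carbonyl carbon. Making that group much larger with two long chains gave a 17-fold lower number from compound 1 to compound 2 (1.24 log units; beyond the scatter), a large drop in the number, while closing the two small groups into the four-membered ring gave a 2.3-fold higher number from compound 1 to compound 3 (0.37 log units; beyond the scatter), a modest rise. The larger ring in compound 4 sits between these cases, so a modest lowering of the number is expected, a 2.2-fold lower number from compound 3 to compound 4 (0.34 log units; beyond the scatter). Compound 4 is therefore estimated at 40 nM in this assay, within a range from 15 nM to 110 nM.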

Compound 4, inhibition constant in the Translocator protein assay: 127 nM
Compound 4: middle estimate off by 3.2-fold (0.50 log units), on the low side, outside the stated range (above it).
By their numbers in the Translocator protein assay, from the lowest: compound 2; then compound 1; then compounds 3 and 4 (each within the scatter of the next).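

Widening the ring from azetidin-1-yl to pyrrolidin-1-yl on the carbonyl carbon leaves the reading in the Translocator protein assay essentially unmoved: compound 3 gives 87.8 nM and compound 4 gives 127 nM (a 1.4-fold higher number from compound 3 to compound 4 (0.16 log units; within the scatter)), so at this place the two ring sizes cannot be told apart. The larger ring also stays well away from the open-chain amides (a 3.4-fold higher number from compound 1 to compound 4 (0.53 log units; beyond the scatter); a 59-fold higher number from compound 2 to compound 4 (1.77 log units; beyond the scatter)), which shows that a bigger group does not by itself lower the number here: among the four compounds, only the dipentylamino group of compound 2 gives a number far lower than the rest, while the pyrrolidin-1-yl group of compound 4 goes against any simple rule based on size. In a physicochemical assay for lipophilicity, read by HPLC, at pH 7.5 (a higher number here means a more lipophilic compound, a lower number a more polar compound), the same ring change also stays within the scatter, with compound 3 at 2.58 and compound 4 at 2.72 (a number 0.14 log units higher from compound 3 to compound 4 (within the scatter)), and nothing measured here explains why the two rings read alike in binding.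

Still open, as far as these compounds go, is whether a piperidin-1-yl or morpholin-4-yl group would read like the two small rings or move toward compound 2. From the compounds shown here alone, it is equally open how the number changes along the open chains, for example with diethylamino or dipropylamino groups, which would show how much chain length is needed to reach the low number of compound 2.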